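Replacing 4-ethylphenyl on the sulfonyl sulfur with 3,5-dichlorophenyl

This account rests on a few compounds, and the source may have more. Where it says the series, first, only, none or still open, it means among the compounds named here.

In a functional assay on DLD-1 cells (Homo sapiens) for antiproliferative activity, read by CellTiter-Glo, with a stated time of 72 h (a higher number here means a weaker inhibitor, a lower number a stronger inhibitor), compound 3 (`CCc1ccc(S(=O)(=O)N2CCC(N3CCC(C)CC3)CC2)cc1`) gives > 5000 nM as a limit of the assay, not a number. Compound 1 (`Cc1noc(C)c1S(=O)(=O)N1CCC(N2CCC(C)CC2)CC1`) gives > 5000 nM as a limit as well. Compound 2 (`CC1CCN(C2CCN(S(=O)(=O)c3cnc(Cl)s3)CC2)CC1`) gives 1800 nM as a measured number. Compound 4 (`CC1CCN(C2CCN(S(=O)(=O)c3cc(Cl)cc(Cl)c3)CC2)CC1`) differs from compound 3 by 3,5-dichlorophenyl in place of 4-ethylphenyl on a sulfonyl sulfur at the sulfonyl sulfur. Two steps at this place bear on it, an at least 2.7-fold lower number from compound 1 to compound 2 (0.44 log units; beyond the scatter) and an at least 2.7-fold higher number from compound 2 to compound 3 (0.44 log units; beyond the scatter) both beyond the scatter, while a step that the two limits leave unreadable from compound 1 to compound 3 gives no size. Among these only compound 2 carries chlorine, and its 1800 nM anchors the expectation. An estimated at least 2.0-fold lower number from compound 3 to compound 4 (0.30 log units; that floor lies within the scatter) is expected, a modest move to a lower number in this assay that may stay at the limit. For compound 4 the estimated value is 2500 nM within an expected range of 800 nM to 5000 nM in this series.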

Compound 4, half-maximal inhibitory concentration: 3400 nM
Compound 4: the middle estimate sits 1.4-fold (0.13 log units) below what was measured; low and high end bracket the measured number.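

In this assay, the two compounds whose group on the sulfonyl sulfur carries chlorine, compound 2 and compound 4, now both give measured numbers, and no compound shown goes against this. The change to 3,5-dichlorophenyl gives a 1.9-fold higher number from compound 2 to compound 4 (0.28 log units; within the scatter), so a six-membered aromatic ring of carbon only also reaches a measured number. Against the other two compounds only floors can be read, an at least 1.4-fold lower number from compound 3 to compound 4 (0.16 log units; that floor lies within the scatter) and an at least 1.4-fold lower number from compound 1 to compound 4 (0.16 log units; that floor lies within the scatter), because their values are limits of the assay: the limit of > 5000 nM in this assay, at which 2 of the 4 values shown sit.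

As far as these compounds go, whether chlorine itself matters stays open. A phenyl carrying trifluoromethyl or nitrile in place of chlorine would test this.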